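The source may hold more compounds than are shown below. What is called first, only, known or untested is meant among the compounds shown, and "the series" means these compounds.

In an ADME assay on microsomes from liver (Homo sapiens) for metabolic stability (on this read-out lower numbers stand for slow clearance and higher numbers for fast clearance), compound 1 (`CCOC(=O)N1C[C@@H]2C[C@H]1CN2c1nc(SC)cc(-c2cnc(N)c(OC(F)F)n2)n1`) gives 12.3 mL/min/kg and compound 2 (`Nc1ncc(-c2cc([C@@H]3CCCO3)nc(N3C[C@@H]4C[C@H]3CO4)n2)nc1OC(F)F`) gives 12.6 mL/min/kg so these two sit within the usual scatter of each other. The change to compound 3 (`Nc1ncc(-c2cc(C3CC3)nc(N3C[C@@H]4C[C@H]3CO4)n2)nc1OC(F)F`) is cyclopropyl in place of oxolan-2-yl on an aromatic carbon. Within the data shown here, no measured pair of compounds shows this swap, so any forecast here is loose. No shift beyond the scatter in either direction is expected in this assay for this swap. The expected step is small (a 1.0-fold higher number from compound 2 to compound 3 (0.01 log units; within the scatter)). For compound 3 the estimated clearance is 13 mL/min/kg (expected range 7 mL/min/kg to 24 mL/min/kg).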

Compound 3, clearance: 11 mL/min/kg
The estimate for compound 3 lay 1.2-fold (0.07 log units) above the measured number; the range from low to high includes it.
By their numbers in this assay, from the lowest: compounds 3, 1 and 2 (each within the scatter of the next).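

On this aromatic carbon, next to the ring nitrogen, cyclopropyl in place of oxolan-2-yl gives a 1.1-fold lower number from compound 2 to compound 3 (0.06 log units; within the scatter) in this assay. The group that leaves carries a hydrogen-bond acceptor and a defined stereocentre, while cyclopropyl carries neither, and in this pair losing both goes with no shift beyond the scatter. Nothing available explains why the two groups read alike. Going by these compounds, whether an amine or a longer alkyl chain at this position would also stay within the scatter remains open, and so does whether this swap would behave the same way on a different core.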